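This account rests on a few compounds, and the source may have more. Where it says the series, first, only, none or still open, it means among the compounds named here.

The series opens with compound 1 `CC(=O)CC/C=C(\C)CCC1=C(C)CCCC1(C)C`, which in a functional assay on OVCAR-3 cells (Homo sapiens) for inhibition (on this read-out higher numbers stand for weaker inhibition of growth and lower numbers for stronger inhibition of growth), gives > 15000 nM; this is a limit of the assay rather than a number, as the limit of > 15000 nM in this assay, at which 1 of the 2 values shown sits, records. Compound 2 `C=C1CCCC(C)(C)C1CC[C@]1(C)CC[C@@H]([C@@H](C)C(=O)O)OO1` is the second measured member. In this assay compound 2 gives > 10000 nM, again a limit and not a number, the one described by the limit of > 10000 nM in this assay, at which 1 of the 2 values shown sits. Both values shown are thus limits, and compound 2 stands among them without a number of its own. For the measured compounds named here, no step between measured compounds is available. Compound 3 `C=C1CCCC(C)(C)C1CC[C@@]1(C)CC[C@H]([C@@H](C)C(=O)O)OO1` is a stereoisomer of compound 2: the two compounds have the same atoms and bonds; at least one stereo element is drawn with a configuration in one of them and without one in the other: 2 of 4 stereo elements differ; a stereocentre at a saturated ring carbon is drawn R in compound 2 and S in compound 3; a stereocentre at a saturated ring carbon is drawn S in compound 2 and R in compound 3. Going by the values given here, a change of configuration alone, with no measured step to lean on, gives no ground to expect a difference beyond the usual scatter, so the step that the limit leaves unreadable from compound 2 to compound 3 is expected to be small. Compound 3 is accordingly estimated at 15000 nM, within 5000 nM to 40000 nM.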

Compound 3, concentration for 50% growth inhibition: 2490 nM
For compound 3 the middle estimate is 6.0-fold (0.78 log units) above the measured one; the whole stated range lies above it.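

In this assay compound 3 carries the only number among the compounds shown, so this read-out now separates two compounds with the same atoms and bonds. The exchange of configuration at the two saturated ring carbons, drawn R and S in compound 2 and S and R in compound 3, goes with an at least 4.0-fold lower number from compound 2 to compound 3 (0.60 log units; beyond the scatter), which shows that configuration at these ring carbons alone can change growth inhibition beyond the scatter. The true size of the step stays unknown, as one end of it is only a limit: the limit of > 10000 nM in this assay, at which 1 of the 3 values shown sits.

The compounds shown change both ring carbons together and leave open which of the two carries the step. Also open, on these data alone, is whether a methyl ester or an amide in place of the carboxylic acid would keep the growth inhibition of compound 3.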